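The compounds below may be only part of what the source reports. "The series", "measured", "known", "first", "only" and "open" are said of these compounds alone.

Compound 3 `CCCCCCCCc1ccc(NC(=O)[C@H](N)[C@H](C)O)cc1` stands at the low end of the three compounds measured in an assay on isolated protein for inhibition of sphingosine kinase 1 (Homo sapiens), read by mobility shift assay; a higher number here means a weaker inhibitor, a lower number a stronger inhibitor: compound 3 gives 2100 nM. Its nearest neighbour is compound 2 `CCCCCCCCc1ccc(NC(=O)[C@@H](N)CO)cc1`, for which compound 2 gives 4300 nM, and the furthest is compound 1 `CCCCCCCCc1ccc(NC(=O)[C@H](N)CO)cc1`, for which compound 1 gives 5000 nM. Compounds 1 and 2 share every atom and bond and differ only in configuration as drawn (the fact that compounds 1 and 2 differ only in the configuration as drawn); the step of a 1.2-fold lower number from compound 1 to compound 2 (0.07 log units; within the scatter) stays within the scatter. The step of a 2.4-fold lower number from compound 1 to compound 3 (0.38 log units; beyond the scatter) and the step of a 2.0-fold lower number from compound 2 to compound 3 (0.31 log units; beyond the scatter) are both modest and both beyond the scatter, and both rest on the added methyl.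

Compound 4 `CCCCCCCCc1ccc(NC[C@@H](N)CO)cc1` has not yet been measured. Against compound 3 it shows (2-amino-3-hydroxypropyl in place of (1-amino-2-hydroxypropyl)carbonyl on a nitrogen on an aromatic ring). Two things change at once here: the methyl that set compound 3 apart from compounds 1 and 2 is gone, and the amide carbonyl is gone as well. The first part is covered by the steps of a 2.4-fold lower number from compound 1 to compound 3 (0.38 log units; beyond the scatter) and a 2.0-fold lower number from compound 2 to compound 3 (0.31 log units; beyond the scatter) run in reverse, which point to a modestly higher number; the second part has no measured counterpart among these compounds. The step of a 2.4-fold higher number from compound 3 to compound 4 (0.38 log units; beyond the scatter) is therefore expected to run toward a weaker inhibitor. In this assay compound 4 is estimated at 5000 nM, with a range from 1800 nM to 15000 nM.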

Compound 4, half-maximal inhibitory concentration: 5000 nM
Beside the measured number, compound 4's estimate shows no gap at the digits printed, and the stated range covers the measured number.
By their numbers in this assay, from the lowest: compound 3; then compounds 2, 1 and 4 (each within the scatter of the next).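

In this assay the amide carbonyl turns out not to be needed for inhibition at this level: with 2-amino-3-hydroxypropyl in place of (1-amino-2-hydroxyethyl)carbonyl on the nitrogen on an aromatic ring, both steps stay within the scatter (a 1.2-fold higher number from compound 2 to compound 4 (0.07 log units; within the scatter) and no change at the digits printed from compound 1 to compound 4 (within the scatter)). The only new step beyond the scatter, and a modest one, is the one that removes the methyl along with the carbonyl (a 2.4-fold higher number from compound 3 to compound 4 (0.38 log units; beyond the scatter)), so among these four compounds compound 3 alone stands apart, and the reduced linker by itself shows no separation from the amides. Nothing measured here gives a cause for any of these steps.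

Among these compounds, it remains open whether a methyl added to the 2-amino-3-hydroxypropyl chain of compound 4 would lower the number as it does among the amides, where it has been seen only with the carbonyl present. Also open, on these data alone, is how a carboxylic acid or a phosphate in place of the hydroxyl, or a longer chain on the ring, would read in this assay.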